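The source may hold more compounds than are shown below. What is called first, only, known or untested is meant among the compounds shown, and "the series" means these compounds.

Working notes on the series.

Within the data shown here, compound 1, `CCO/N=C/Nc1cc(Cl)c(SCC)c(Cl)c1`, gives 4.6 in a physicochemical assay for lipophilicity, measured as octanol-water partition (a higher number here means a more lipophilic compound, a lower number a more polar compound), and stands highest of the three numbers measured so far. Compound 2, `CCO/N=C/Nc1cc(Cl)c(S(=O)(=O)CC)c(Cl)c1`, gives 2.8 in this assay, and compound 3, `CC#CCOc1c(Cl)cc(N/C=N/OCC)cc1Cl`, gives 4. The two steps away from compound 1 are both downward: a number 1.80 log units lower from compound 1 to compound 2 (beyond the scatter), and a number 0.60 log units lower from compound 1 to compound 3 (beyond the scatter). Between the other two, a number 1.20 log units higher from compound 2 to compound 3 (beyond the scatter).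

Compound 4, `CCO/N=C/Nc1cc(Cl)c(OCC#N)c(Cl)c1`, is not yet measured. Its change from compound 1 is cyanomethoxy in place of ethylsulfanyl on an aromatic carbon. The step from compound 1 to compound 3 bears on it most directly, since an oxygen-linked chain again takes the place of ethylsulfanyl, and that step was modest. The entering group, however, brings a second hydrogen-bond acceptor through its nitrile, which points to a drop beyond that seen from compound 1 to compound 3, though smaller than the large drop from compound 1 to compound 2. A step of a number 1.50 log units lower from compound 1 to compound 4 (beyond the scatter) is therefore expected in this assay for compound 4. Compound 4 is estimated at 3.1, within a range of 2.5 to 3.7.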

Compound 4, partition coefficient: 3.1
Estimate against measurement, compound 4: no gap at the digits printed, and the stated range covers the measured number.
By their numbers in this assay, from the lowest: compounds 2 and 4 (each within the scatter of the next); then compound 3; then compound 1.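

Among the chains linked through oxygen on this aromatic carbon, the far end of the chain now proves to matter in this assay: with cyano in place of prop-1-yn-1-yl, the result is a number 0.90 log units lower from compound 3 to compound 4 (beyond the scatter), a change that the earlier compounds did not test. Against ethylsulfanyl, the new group gives a number 1.50 log units lower from compound 1 to compound 4 (beyond the scatter), while a number 0.30 log units higher from compound 2 to compound 4 (within the scatter) leaves cyanomethoxy and ethylsulfonyl not separable in this assay, despite their different linking atoms. No measurement on hand accounts for these steps.

The compounds shown leave open how methoxy, without the nitrile, would stand against cyanomethoxy on this carbon. Also open, from the compounds shown here alone, is where an amine, a carboxylic acid or a longer chain ending in a nitrile would fall in this assay at this position.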